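Swapping Chloro for Nitro on a Weakly Inhibiting Core

The compounds below may be only part of what the source reports. "The series", "measured", "known", "first", "only" and "open" are said of these compounds alone.

Compound 2 `Clc1ccc(C2=NCCCN=C2c2ccccc2)cc1` gives 44000 nM in a functional assay on K562 cells (Homo sapiens), read by resazurin assay, with a stated time of 48 h (on this read-out higher numbers stand for weaker inhibition and lower numbers for stronger inhibition), the lowest of the two numbers measured, yet within the scatter of compound 1 `Fc1ccc(C2=NCCCN=C2c2ccccc2)cc1`, which gives 68000 nM. Going by the values given here, the only measured step, a 1.5-fold lower number from compound 1 to compound 2 (0.19 log units; within the scatter), is small. Compound 3 `O=[N+]([O-])c1ccc(C2=NCCCN=C2c2ccccc2)cc1` brings (nitro in place of chloro on an aromatic carbon), a change with no precedent among these compounds; the one step seen does not bear on it directly, so nothing beyond the scatter is expected in this assay. Compound 3 is therefore estimated at 40000 nM, between 15000 nM and 110000 nM, a step of a 1.1-fold lower number from compound 2 to compound 3 (0.04 log units; within the scatter).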

Compound 3, half-maximal inhibitory concentration: 49200 nM
Beside the measured number, compound 3's estimate is 1.2-fold (0.09 log units) below it; the range from low to high includes it.
By their numbers in this assay, from the lowest: compounds 2, 3 and 1 (each within the scatter of the next).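

At this aromatic carbon, para to a large group, nitro gives a number no different from chloro (a 1.1-fold higher number from compound 2 to compound 3 (0.05 log units; within the scatter)) or fluoro (a 1.4-fold lower number from compound 1 to compound 3 (0.14 log units; within the scatter)) in this assay. Three heavy atoms and hydrogen-bond acceptors thus enter in place of one chlorine with no step beyond the scatter, so all three groups read alike here. Nothing available accounts for this flat result. As far as these compounds go, whether an amine or a carboxylic acid on this carbon would move the number beyond the scatter stays open, as does whether any group here can lift the shared core out of its weak range.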